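The source may hold more compounds than are shown below. What is called first, only, known or untested is meant among the compounds shown, and "the series" means these compounds.

Compound 1 `O=C(OC1CCC(CN2CCN(c3cc(=O)c4cc(C(F)(F)F)cc([N+](=O)[O-])c4s3)CC2)CC1)c1ccccc1` stands lowest of the three compounds measured in an ADME assay on cells (Hepatocyte, Homo sapiens) for metabolic stability, with a stated time of 30 min; on this read-out higher numbers stand for a more stable compound and lower numbers for a less stable compound: in this assay compound 1 gives 56.4%, while compound 2 `O=c1cc(N2CCN(CC3CCC(NS(=O)(=O)c4ccccc4)CC3)CC2)sc2c([N+](=O)[O-])cc(C(F)(F)F)cc12` gives 90.8% and compound 3 `O=c1cc(N2CCN(CC3CCCCC3)CC2)sc2c([N+](=O)[O-])cc(C(F)(F)F)cc12` gives 82.4%. The two steps that lead away from compound 1 are both beyond the scatter: a number 34.4 percentage points higher from compound 1 to compound 2 (beyond the scatter), and a number 26 percentage points higher from compound 1 to compound 3 (beyond the scatter). Between the two higher compounds the step is a number 8.4 percentage points lower from compound 2 to compound 3 (within the scatter). All three of these steps concern the group on a saturated ring carbon; they say nothing about the aromatic ring of the benzoyloxy group.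

Compound 4 `O=C(OC1CCC(CN2CCN(c3cc(=O)c4cc(C(F)(F)F)cc([N+](=O)[O-])c4s3)CC2)CC1)c1ccc(F)cc1` differs from compound 1 in exactly that ring: fluoro in place of hydrogen on an aromatic carbon. Among the measured compounds shown here, no measured step bears on this change, because the benzoyloxy group is carried unchanged by compound 1 and removed or replaced in compounds 2 and 3. For the measured compounds named here, with no step to lean on, a change of a single fluorine on the aromatic ring is expected to move the number by no more than the scatter in either direction. The step of a number 0.6 percentage points higher from compound 1 to compound 4 (within the scatter) is therefore expected to lie within the scatter. Compound 4 is accordingly estimated to give 57% in this assay, with a range from 40% to 74%.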

Compound 4, percent of the compound remaining: 3%
Beside the measured number, compound 4's estimate is 54 percentage points above it; measured number outside the range, below it.
By their numbers in this assay, from the lowest: compound 4; then compound 1; then compounds 3 and 2 (each within the scatter of the next).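

In this assay, the aromatic ring of the benzoyloxy group turns out to be a highly sensitive place: a single fluoro in place of hydrogen, on an aromatic carbon para to a large group, gives a large drop (a number 53.4 percentage points lower from compound 1 to compound 4 (beyond the scatter)), so the earlier steps, which only removed or replaced the whole group on the saturated ring carbon, had not shown that the outer ring matters at all. Set against the compounds without a benzoyloxy group, the fluorinated group leaves a far wider gap, with ((4-fluorophenyl)carbonyl)oxy in place of hydrogen giving one large step (a number 79.4 percentage points lower from compound 3 to compound 4 (beyond the scatter)) and the same group in place of (phenylsulfonyl)amino giving another (a number 87.8 percentage points lower from compound 2 to compound 4 (beyond the scatter)). Nothing at hand accounts for so large a shift from one added atom.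

The compounds shown leave open whether the drop belongs to fluoro itself or to any substituent at this carbon, which chloro, methyl or methoxy in the same place would test. They also leave open whether fluoro on the phenyl ring of the (phenylsulfonyl)amino group of compound 2 would move the number in the same way.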